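Pyridazine series: replacing the aryl substituent on the shared core

This account rests on a few compounds, and the source may have more. Where it says the series, first, only, none or still open, it means among the compounds named here.

Measured compounds:
compound 1, `Cc1cc(-c2ccc(F)cc2)nnc1N1CCN(c2ncccn2)CC1`, 76300 nM
compound 2, `COc1ccc(-c2cc(C)c(N3CCN(c4ncccn4)CC3)nn2)cc1`, 5200 nM

Two compounds have been run in a functional assay on BV-2 cells (Mus musculus) for inhibition, read by ELISA, with a stated time of 16 h; on this read-out lower numbers stand for stronger inhibition and higher numbers for weaker inhibition. Compound 1 gives 76300 nM; compound 2 gives 5200 nM. Among the measured compounds shown here, the single step between them, a 15-fold lower number from compound 1 to compound 2 (1.17 log units; beyond the scatter), places compound 2 at the lowest of the two numbers, with compound 1 the nearest and its number well beyond the scatter above it.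

Compound 3, `Cc1cc(-c2cc3ccccc3s2)nnc1N1CCN(c2ncccn2)CC1`, has not yet been measured. The change from compound 2 is 1-benzothiophen-2-yl in place of 4-methoxyphenyl on an aromatic carbon. For the measured compounds named here, the one measured step, a 15-fold lower number from compound 1 to compound 2 (1.17 log units; beyond the scatter), swaps substituents on the same six-membered ring of carbon only and does not speak to the exchange of that whole ring for a 1-benzothiophen-2-yl group; nothing measured here bears on it directly. Going by the values given here, with no step to lean on, the expectation for compound 3 is kept close to compound 2 and given a wide range, so that the step of a 1.3-fold lower number from compound 2 to compound 3 (0.11 log units; within the scatter) is not expected to exceed the scatter. Compound 3 is estimated at 4000 nM, with a range from 800 nM to 20000 nM.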

Compound 3, half-maximal inhibitory concentration: 24900 nM
Compound 3: the middle estimate sits 6.2-fold (0.79 log units) below what was measured; measured number outside the range, above it.
By their numbers in this assay, from the lowest: compound 2; then compound 3; then compound 1.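

In this assay, this position on the shared core is not limited to changes on a phenyl ring: the whole ring can be exchanged for 1-benzothiophen-2-yl, and the number still falls between those of the two phenyl compounds. That exchange gives a 4.8-fold higher number from compound 2 to compound 3 (0.68 log units; beyond the scatter) and a 3.1-fold lower number from compound 1 to compound 3 (0.49 log units; beyond the scatter), so 1-benzothiophen-2-yl is separated from both 4-methoxyphenyl and 4-fluorophenyl by steps beyond the scatter, and keeping a carbon-only six-membered aromatic ring does not by itself decide the order, since compound 2 and compound 1 lie on either side of compound 3. No accompanying measurement accounts for this order.

Going by these compounds, it remains open whether a methoxy group carried on the 1-benzothiophen-2-yl group would move the number as the methoxy in place of fluoro did on the phenyl ring, and whether 1-benzofuran-2-yl, with oxygen in place of sulfur, would stand with compound 3. Equally open, on these data alone, is whether an amine or a carboxylic acid at the position held by methoxy in compound 2 would give a lower or a higher number in this assay.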